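The source may hold more compounds than are shown below. What is called first, only, known or untested is meant among the compounds shown, and "the series" means these compounds.

Measured so far in a functional assay on MDA-MB-231 cells (Homo sapiens) for inhibition, read by MTT assay, with a stated time of 72 h; on this read-out higher numbers stand for weaker inhibition and lower numbers for stronger inhibition:
compound 1 `O=C(CSc1nc(Nc2ccccc2)c2ccccc2n1)Nc1ccccc1Cl` — 24400 nM
compound 2 `O=C(CSc1nc(Nc2ccccc2)c2ccccc2n1)Nc1cccc(Br)c1` — 17500 nM

Compound 1 and compound 2 sit within the scatter of each other: the step of a 1.4-fold lower number from compound 1 to compound 2 (0.14 log units; within the scatter) is the only one known, and it tells little about the amide-type nitrogen substituent. Compound 3 `CCc1cccc(NC(=O)CSc2nc(Nc3ccccc3)c3ccccc3n2)c1` differs from compound 1 by 3-ethylphenyl in place of 2-chlorophenyl on an amide-type nitrogen. Within the data shown here, no measured step involves a 3-ethylphenyl, so the sole comparison is the small step from compound 1 to compound 2; on that basis no change beyond the scatter is expected in this assay. Compound 3 is therefore estimated at 20000 nM, range 8000 nM to 50000 nM, the expected step being a 1.2-fold lower number from compound 1 to compound 3 (0.09 log units; within the scatter).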

Compound 3, half-maximal inhibitory concentration: 12400 nM
Estimate against measurement, compound 3: 1.6-fold (0.21 log units) above; the measured number falls inside the stated range.
By their numbers in this assay, from the lowest: compounds 3, 2 and 1 (each within the scatter of the next).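

In this assay, the swap to 3-ethylphenyl on the amide-type nitrogen gives a 2.0-fold lower number from compound 1 to compound 3 (0.29 log units; within the scatter), and ethyl in place of bromo on an aromatic carbon gives a 1.4-fold lower number from compound 2 to compound 3 (0.15 log units; within the scatter). The position therefore now holds a halogen-free alkyl-bearing phenyl as well as the two halogen-bearing phenyls, with all three compounds lying within the scatter of the next in line. No measured evidence bears on these steps.

The compounds shown leave open whether an amine, a carboxylic acid or a longer chain on this phenyl would move the number beyond the scatter.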